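Replacing 3,4-dichlorophenyl with 4-hydroxy-3-methoxyphenyl

This account rests on a few compounds, and the source may have more. Where it says the series, first, only, none or still open, it means among the compounds named here.

Compound 1 (`COc1cccc(/C=C2\CCC/C(=C\c3ccc(OC)c(OC)c3)C2=O)c1`): 4600 nM
Compound 2 (`COc1ccc(/C=C2\CCC/C(=C\c3ccc(Cl)c(Cl)c3)C2=O)cc1OC`): 4400 nM

For the measured compounds named here, in a functional assay on MCF7 cells (Homo sapiens) for cytotoxicity, read by MTT assay, with a stated time of 72 h (on this read-out higher numbers stand for weaker inhibition and lower numbers for stronger inhibition), compound 2 gives 4400 nM and stands within the scatter of compound 1, the only other measured compound. Compound 3 (`COc1cc(/C=C2\CCC/C(=C\c3ccc(OC)c(OC)c3)C2=O)ccc1O`) carries 4-hydroxy-3-methoxyphenyl in place of 3,4-dichlorophenyl on a double-bonded chain carbon bound to a double-bonded ring carbon. Going by the values given here, one measured step bears on this place, 3,4-dichlorophenyl in place of 3-methoxyphenyl (a 1.0-fold lower number from compound 1 to compound 2 (0.02 log units; within the scatter)), and it stayed within the scatter. In this assay the expected change therefore also stays within the scatter (a 1.3-fold lower number from compound 2 to compound 3 (0.10 log units; within the scatter)). Compound 3 is estimated at 3500 nM (expected range 1300 nM to 9500 nM).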

Compound 3, half-maximal inhibitory concentration: 7900 nM
Compound 3: middle estimate off by 2.3-fold (0.35 log units), on the low side; measured number inside the range.
By their numbers in this assay, from the lowest: compounds 2, 1 and 3 (each within the scatter of the next).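

In this assay, 4-hydroxy-3-methoxyphenyl in place of 3,4-dichlorophenyl on a double-bonded chain carbon bound to a double-bonded ring carbon stays within the scatter (a 1.8-fold higher number from compound 2 to compound 3 (0.25 log units; within the scatter)), so a group with a hydrogen-bond donor can enter this place without a step beyond it. Hydroxy in place of hydrogen on an aromatic carbon also stays within the scatter (a 1.7-fold higher number from compound 1 to compound 3 (0.23 log units; within the scatter)). Going by these compounds, whether an amine or a carboxylic acid at this place would give a step beyond the scatter remains open. Nothing given here accounts for these steps.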